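Removing a Fluorine from the Aryl Sulfone of Compound 1

A few compounds are considered here, and "the series" means these few. Any claim that something is new, unique, unknown or untested is made for them only; others in the source may bear on it.

Of the compounds shown here, three have been measured so far in a functional assay on A2780 cells (Homo sapiens) for inhibition, read by sulforhodamine B assay, with a stated time of 72 h; on this read-out higher numbers stand for weaker inhibition and lower numbers for stronger inhibition. Compound 1, `O=C(NCc1ccc(S(=O)(=O)c2cccc(F)c2)cc1)c1cc2cnccc2[nH]1`, gives 11 nM in this assay. Compound 3, `O=C(NCc1ccc(S(=O)(=O)c2cc(F)cc(F)c2)cc1)c1cnc2nccn2c1`, gives 3 nM in this assay, a lower number than compound 1 by a margin beyond the usual scatter, so of the two numbers shown compound 1 stands as the higher one. Compound 2, `O=C(NCc1ccc(S(=O)(=O)N2CCCCC2)cc1)c1ccn2ccnc2c1`, reaches only a limit of the assay, reported as > 10000 nM, which is the limit of > 10000 nM in this assay, at which 1 of the 3 values shown sits, and not a number to be set against the others.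

The next compound, compound 4, `O=C(NCc1ccc(S(=O)(=O)c2ccccc2)cc1)c1cc2cnccc2[nH]1`, differs from compound 1 by a single change: hydrogen in place of fluoro on an aromatic carbon. No measured pair here isolates this kind of change, so no shown step speaks to it directly. A single fluorine leaving a carbon-only aromatic ring is a modest alteration, and the step of a 1.8-fold higher number from compound 1 to compound 4 (0.26 log units; within the scatter) is expected to be small, close to or within the usual scatter, with the number drifting slightly upward if anywhere. Compound 4 is therefore estimated to give about 20 nM in this assay, most likely between 6 nM and 60 nM.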

Compound 4, half-maximal inhibitory concentration: 18 nM
Beside the measured number, compound 4's estimate is 1.1-fold (0.05 log units) above it; low and high end bracket the measured number.
By their numbers in this assay, from the lowest: compound 3; then compounds 1 and 4 (each within the scatter of the next). At a limit, above all of these: compound 2.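

Taking the fluoro away, so that 3-fluorophenyl becomes phenyl, gives in this assay a 1.6-fold higher number from compound 1 to compound 4 (0.21 log units; within the scatter). This is the first pair shown that differs in one place only, and it shows that, on the core of compound 1, this fluoro can be replaced by hydrogen with no change that can be told apart from the scatter of repeated measurements. Nothing measured here bears on why the step has this size.

Still open, from the compounds shown here alone, is whether a different group at this same position on the aromatic ring, such as chloro, methoxy or an amine, would shift the number beyond the scatter. Also open, going by these compounds, is whether removing a fluoro from compound 3, which has a different core, would give a similarly small step.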